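A side-chain exchange from compound 2 to compound 3

This account rests on a few compounds, and the source may have more. Where it says the series, first, only, none or still open, it means among the compounds named here.

- Compound 1 `C[C@@H](NC(=O)C1CCN(C(=O)c2cc3ccccc3n2Cc2ccc(Cl)cc2)CC1)c1ccncc1`: 92300 nM
- Compound 2 `O=C(NCCn1ccnc1)C1CCN(C(=O)c2cc3ccccc3n2Cc2ccc(Cl)cc2)CC1`: 99600 nM

For the measured compounds named here, in an ADME assay on BE(2)-C cells (Homo sapiens) for cytotoxicity, read by MTT assay, with a stated time of 20 h (on this read-out lower numbers stand for higher toxicity in this test and higher numbers for lower toxicity in this test), compound 2 gives 99600 nM and cannot be separated from compound 1, since the only measured step, a 1.1-fold higher number from compound 1 to compound 2 (0.03 log units; within the scatter), stays within the scatter. Compound 3 `O=C(c1cc2ccccc2n1Cc1ccc(Cl)cc1)N1CCC(C(=O)N2CCC[C@H]2CO)CC1` has not yet been measured. Its structure differs from that of compound 2 as follows: 2-(hydroxymethyl)pyrrolidin-1-yl in place of (2-(1H-imidazol-1-yl)ethyl)amino on a carbonyl carbon. Going by the values given here, no measured step covers this exchange directly. Among the compounds with values here, the one available step, with 2-(1H-imidazol-1-yl)ethyl in place of 1-(pyridin-4-yl)ethyl on an amide-type nitrogen, bears on it only loosely, and its small size is the sole guide. No shift beyond the scatter is therefore expected in this assay, and the estimated step is a 1.1-fold lower number from compound 2 to compound 3 (0.04 log units; within the scatter). For compound 3 the expected value is 90000 nM, with an estimated range of 45000 nM to 170000 nM.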

Compound 3, half-maximal cytotoxic concentration: 98900 nM
For compound 3 the middle estimate is 1.1-fold (0.04 log units) below the measured one; the range from low to high includes it.
By their numbers in this assay, from the lowest: compounds 1, 3 and 2 (each within the scatter of the next).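

In this assay, 2-(hydroxymethyl)pyrrolidin-1-yl in place of (2-(1H-imidazol-1-yl)ethyl)amino on the carbonyl carbon gives a 1.0-fold lower number from compound 2 to compound 3 (0.00 log units; within the scatter), and in place of (1-(pyridin-4-yl)ethyl)amino it gives a 1.1-fold higher number from compound 1 to compound 3 (0.03 log units; within the scatter). Both earlier compounds carry an aromatic ring in this side chain, so they showed only an exchange of one aromatic side chain for another; compound 3 extends the flat result to a five-membered non-aromatic ring bearing a hydroxymethyl group. No measured evidence is available to account for this absence of a shift.

From the compounds shown here alone, whether a side chain ending in a primary amine or a carboxylic acid would move the number beyond the scatter remains open. So does the effect of the opposite configuration at the defined stereocentre of the pyrrolidine.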